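This account rests on a few compounds, and the source may have more. Where it says the series, first, only, none or still open, it means among the compounds named here.

Measured so far in a functional assay on HT-29 cells (Homo sapiens) for antiproliferative activity, read by MTT assay, with a stated time of 72 h; a higher number here means a weaker inhibitor, a lower number a stronger inhibitor:
compound 1 `COc1ccc(N2CCN(C(=S)SCc3ccc4nc(N)nc(N)c4c3)CC2)cc1`: 1770 nM
compound 2 `Cc1ccccc1N1CCN(C(=S)SCc2ccc3nc(N)nc(N)c3c2)CC1`: 2950 nM

Among the compounds with values here, compound 1 carries the lowest of the two numbers, although the one measured step, a 1.7-fold higher number from compound 1 to compound 2 (0.22 log units; within the scatter), lies within the scatter, so the two compounds cannot be ranked. Compound 3 `Nc1nc(N)c2cc(CSC(=S)N3CCN(c4ccccn4)CC3)ccc2n1` differs from compound 1 in one place: pyridin-2-yl in place of 4-methoxyphenyl on an amine nitrogen in a ring. Within the data shown here, the only measured step, a 1.7-fold higher number from compound 1 to compound 2 (0.22 log units; within the scatter), concerns a different replacement at the same ring nitrogen and was within the scatter, so for compound 3 no step beyond the scatter is expected in this assay. Compound 3 is therefore estimated at 2000 nM, with a range from 800 nM to 5000 nM, which is expected to mean a 1.1-fold higher number from compound 1 to compound 3 (0.05 log units; within the scatter).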

Compound 3, half-maximal inhibitory concentration: 6200 nM
For compound 3 the middle estimate is 3.1-fold (0.49 log units) below the measured one; measured number above the stated range.
By their numbers in this assay, from the lowest: compounds 1 and 2 (each within the scatter of the next); then compound 3.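

At this ring nitrogen, the choice of aromatic ring can change the result in this assay: pyridin-2-yl brings a 3.5-fold higher number from compound 1 to compound 3 (0.54 log units; beyond the scatter) and a 2.1-fold higher number from compound 2 to compound 3 (0.32 log units; beyond the scatter), both modest but beyond the scatter. Compound 3 thus separates from compound 1 and compound 2, which cannot be ranked against each other. Nothing available explains this difference.

As far as these compounds go, it remains open whether the ring nitrogen of pyridin-2-yl matters or whether the missing methoxy and methyl groups do. An unsubstituted phenyl group or a pyridin-4-yl group at this position could help separate these possibilities.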